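This account rests on a few compounds, and the source may have more. Where it says the series, first, only, none or still open, it means among the compounds named here.

Working notes on the series. In a functional assay for inhibition, read by spectrophotometry, with a stated time of 10 min (on this read-out lower numbers stand for an effect already at smaller amounts and higher numbers for an effect only at larger amounts of compound), compound 1 (`CCN(CC)C(=O)COc1cc(O)c2c(=O)c(O)c(-c3ccc4c(c3)OC(c3ccc(OCC(=O)N(CC)CC)c(OC)c3)C(CO)O4)oc2c1`) gives 59900 nM and compound 2 (`COc1cc(C2Oc3cc(-c4oc5cc(OCC=C(C)C)cc(O)c5c(=O)c4O)ccc3OC2CO)ccc1O`) gives 137000 nM as the higher of the two numbers, a gap beyond the scatter. Compound 3 (`CCN(CC)C(=O)COc1cc(O)c2c(=O)c(O)c(-c3ccc4c(c3)OC(c3ccc(O)c(OC)c3)C(CO)O4)oc2c1`) departs from compound 2 by diethylcarbamoyl in place of 2-methylprop-1-en-1-yl on a saturated chain carbon bound to an oxygen on an aromatic ring in one place, with (diethylcarbamoyl)methoxy replacing (3-methylbut-2-en-1-yl)oxy. Among the measured compounds shown here, no measured pair isolates this change, so the expectation in this assay rests on thin evidence. Compound 1 also carries (diethylcarbamoyl)methoxy and reads 59900 nM in that assay, though it differs from compound 3 in a second place. A modest move toward lower numbers is therefore expected, and it may not clear the scatter. The expected size is a 1.8-fold lower number from compound 2 to compound 3 (0.26 log units; within the scatter) in this estimate. For compound 3 the estimated value is 75000 nM with an expected range of 30000 nM to 170000 nM in this series.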

Compound 3, half-maximal effective concentration: 113000 nM
The estimate for compound 3 lay 1.5-fold (0.18 log units) below the measured number; low and high end bracket the measured number.
By their numbers in this assay, from the lowest: compounds 1, 3 and 2 (each within the scatter of the next, the first and the last beyond it).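

In this assay, among the compounds shown here, diethylcarbamoyl in place of 2-methylprop-1-en-1-yl on a saturated chain carbon bound to an oxygen on an aromatic ring gives a 1.2-fold lower number from compound 2 to compound 3 (0.08 log units; within the scatter), so the first isolated reading of this change does not separate the two groups at this position. Hydrogen in place of (diethylcarbamoyl)methyl on an oxygen on an aromatic ring gives a 1.9-fold higher number from compound 1 to compound 3 (0.28 log units; within the scatter), so the second place likewise shows no separation in this pair. Nothing at hand offers an explanation for either reading.

On these data alone, whether an amine, a carboxylic acid or a longer chain on that oxygen would read apart from these groups stays open. Also open, as far as these compounds go, is whether either step would keep its size with a different group at the other place.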